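The compounds below may be only part of what the source reports. "The series", "measured", "known", "first", "only" and "open" are said of these compounds alone.

In an assay on CHO cells for displacement of a labelled ligand from adenosine receptor A1 (Homo sapiens), read by scintillation counting, tested at 10 uM (on this read-out lower numbers stand for less inhibition and higher numbers for more inhibition at the one concentration tested (going by the name of the read-out)), compound 2 `Cc1ccc(-c2sc(N)c(C(=O)c3ccc(Cl)cc3)c2CC(C)(C)C)cc1` gives 1%. Its nearest neighbour, compound 1 `CC(C)(C)Cc1c(-c2ccc(F)cc2F)sc(N)c1C(=O)c1ccc(Cl)cc1`, gives 1% in this assay, so the step of no change at the digits printed from compound 1 to compound 2 (within the scatter) left the read-out where it was. Compound 3 `Cc1cccc(-c2sc(N)c(C(=O)c3ccc(Cl)cc3)c2CC(C)(C)C)c1` is the next step: 3-methylphenyl in place of 4-methylphenyl on an aromatic carbon. Within the data shown here, only one measured step bears on this change, and it swapped one aromatic group for another without moving the number beyond the scatter. The same is therefore expected here, the step of no change at the digits printed from compound 2 to compound 3 (within the scatter) being no change beyond the scatter. Compound 3 is estimated to give 1%, with a range from 0% to 10%.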

Compound 3, a percentage reported as inhibition, at one concentration (the size of the read-out at that concentration, not a potency): 1%
Compound 3: middle estimate and measured number agree at the digits printed; measured number inside the range.
By their numbers in this assay, from the lowest: compounds 1, 2 and 3 (each within the scatter of the next).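

In this assay, the earlier pair exchanged one substituted phenyl group for another, while this pair shows that the place of the methyl on the phenyl group also leaves the read-out flat, with no change at the digits printed from compound 2 to compound 3 (within the scatter) on the aromatic carbon next to the ring sulfur. The comparison with the difluorinated compound agrees, with no change at the digits printed from compound 1 to compound 3 (within the scatter). No measurement available here explains this flat result. Going by these compounds, whether a phenyl group carrying an amine or a carboxylic acid at this position would raise the inhibition stays open, as does the effect of a longer chain in place of the neopentyl group.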